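Aryl-substituted diaminoquinazolines: removing the para amino group

The source may report more compounds than this note shows. Statements on the series, on what has been measured and on what is new or still open speak of the compounds shown alone.

Measured so far:
- compound 1 `CC(=O)c1cccc(-c2ccc3c(N)nc(N)nc3c2)c1`: 323 nM
- compound 2 `Nc1ccc(-c2ccc3c(N)nc(N)nc3c2)cc1`: 702 nM

The two measured compounds share a core carrying a phenyl group. In an assay on isolated protein for inhibition of Dihydrofolate reductase (Homo sapiens), read by spectrophotometry, using NADPH, with a stated time of 10 min (on this read-out higher numbers stand for weaker inhibition and lower numbers for stronger inhibition), compound 1 gives 323 nM; compound 2 gives 702 nM in this assay. Compound 2 thus stands at the higher of the two numbers, and the gap to compound 1 lies beyond the usual scatter, so compound 2 is the weaker inhibitor of the pair. Among the compounds with values here, the two differ in more than one place, so no single step is read from them.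

Compound 3 `Nc1nc(N)c2ccc(-c3ccccc3)cc2n1` has not yet been measured. It differs from compound 2 as follows: hydrogen in place of amino on an aromatic carbon. Within the data shown here, no measured pair shows this exact change, so its effect is uncertain. The expectation is a step from compound 2 to compound 3 of a 1.4-fold lower number from compound 2 to compound 3 (0.15 log units; within the scatter), small and probably toward a lower number, though it may fall within the scatter. For compound 3 the estimate in this assay is 500 nM, with a range from 200 nM to 1500 nM.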

Compound 3, inhibition constant: 743 nM
The estimate for compound 3 lay 1.5-fold (0.17 log units) below the measured number, and the stated range covers the measured number.
By their numbers in this assay, from the lowest: compound 1; then compounds 2 and 3 (each within the scatter of the next).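

In this assay, hydrogen in place of amino on an aromatic carbon, para to a large group, gives a 1.1-fold higher number from compound 2 to compound 3 (0.02 log units; within the scatter), so at this position the amino group cannot be told apart from hydrogen on this read-out. Compound 3 also gives the shared core with an unsubstituted phenyl group a reference point, and against it the acetyl group of compound 1 does stand out: hydrogen in place of acetyl gives a 2.3-fold higher number from compound 1 to compound 3 (0.36 log units; beyond the scatter), a modest step toward weaker inhibition. Of the two groups compared with hydrogen, only acetyl separates from it beyond the scatter, and no supporting data bear on the reason for either step.

On these data alone, with a single acetyl compound and a single amino compound, it remains open whether the modest step belongs to the acetyl group itself or to the carbon that carries it, and how acetyl would read para to the large group. A carboxylic acid, a nitrile or a longer chain at that position would test whether the match between amino and hydrogen extends beyond these two groups.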